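A few compounds are considered here, and "the series" means these few. Any claim that something is new, unique, unknown or untested is made for them only; others in the source may bear on it.

Of the compounds shown here, three have been measured so far in an assay on J774 cells for inhibition of prostaglandin G/H synthase 1 (Mus musculus), read by immunoassay, with stated times of 15 min and 30 min; a lower number here means a stronger inhibitor, a higher number a weaker inhibitor. Compound 1, `Cc1c(CCSCCO[N+](=O)[O-])cc(-c2ccc(S(C)(=O)=O)cc2)n1-c1ccc(F)c(F)c1`, carries a 2-(nitrooxy)ethyl chain on sulfur. In this assay compound 1 returns only > 10000 nM, which is a limit of the assay and not a number. Compound 2, `Cc1c(CCSCCO)cc(-c2ccc(S(C)(=O)=O)cc2)n1-c1ccc(F)c(F)c1`, differs from compound 1 by hydrogen in place of nitro on an oxygen on a saturated carbon. In this assay compound 2 likewise returns a limit, > 10000 nM. The step that the two limits leave unreadable from compound 1 to compound 2 is therefore one whose size cannot be read from these two results. Compound 3, `Cc1c(CC[S+]([O-])CCO[N+](=O)[O-])cc(-c2ccc(S(C)(=O)=O)cc2)n1-c1ccccc1`, is built on a different core, and how its core differs from that of compound 1 is not broken down here. In this assay compound 3 also stops at a limit, > 10000 nM. The three measured values thus share one feature: the limit of > 10000 nM in this assay, at which 3 of the 3 values shown sit.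

Compound 4, `Cc1c(CC[S+]([O-])CCO)cc(-c2ccc(S(C)(=O)=O)cc2)n1-c1ccccc1`, has not yet been measured in this assay. It differs from compound 3 by hydrogen in place of nitro on an oxygen on a saturated carbon, which is the same change as that from compound 1 to compound 2, made at the same place. Because all three measured compounds sit at the limit of > 10000 nM in this assay, at which 3 of the 3 values shown sit, the earlier step offers no size to carry over, and nothing in the measured compounds points to a number within the range of the assay. Compound 4 is therefore expected to fall around 30000 nM, most likely again as a limit, within a range from 10000 nM to 100000 nM. The step that the limit leaves unreadable from compound 3 to compound 4 that this estimate means is expected to be as unreadable as the one before it.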

Compound 4, half-maximal inhibitory concentration: > 10000 nM
Compound 4 was reported as a limit; the forecaster's own chance of this, stated with the estimate: 90%; the middle value does not contradict the limit.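

In this assay compound 4 gives > 10000 nM, which is a limit of the assay and not a number. Compound 3 also stands at a limit, so no size can be read for the change from nitrooxy to hydroxy between compound 3 and compound 4. The compounds shown leave open how strongly any of them inhibits in this assay, for they share a single result: the limit of > 10000 nM in this assay, at which 4 of the 4 values shown sit.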